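Swapping pyridinyl for difluorophenyl on the piperazine nitrogen

This account rests on a few compounds, and the source may have more. Where it says the series, first, only, none or still open, it means among the compounds named here.

Measured in a functional assay on CHO cells with adenosine receptor A1 (Homo sapiens) as the target, read by cAMP accumulation and immunoassay, with a stated time of 6 min, tested at 10 uM; on this read-out higher numbers stand for a weaker effect at the one concentration tested and lower numbers for a stronger effect:
- compound 1, `Nc1scc(CN2CCN(c3cccc(Cl)c3Cl)CC2)c1C(=O)c1ccc(Cl)cc1`, gives -77%
- compound 2, `Nc1scc(CN2CCN(c3ccc(Cl)cc3F)CC2)c1C(=O)c1ccc(Cl)cc1`, gives -81%
- compound 3, `Nc1scc(CN2CCN(c3ccncc3)CC2)c1C(=O)c1ccc(Cl)cc1`, gives -15%

Compound 3 stands highest of the three numbers. Its nearest neighbour is compound 1, and the step of a number 62 percentage points higher from compound 1 to compound 3 (beyond the scatter) is beyond the scatter; the step of a number 66 percentage points higher from compound 2 to compound 3 (beyond the scatter) is larger still. Compound 4, `Nc1scc(CN2CCN(c3cc(F)ccc3F)CC2)c1C(=O)c1ccc(Cl)cc1`, is reached from compound 3 by 2,5-difluorophenyl in place of pyridin-4-yl on an amine nitrogen in a ring.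

For the measured compounds named here, two measured steps bear on this change. Both a number 62 percentage points higher from compound 1 to compound 3 (beyond the scatter) and a number 66 percentage points higher from compound 2 to compound 3 (beyond the scatter) describe the entry of pyridin-4-yl in place of a halogenated phenyl, and both were large rises. The change to compound 4 runs the other way: a halogenated phenyl enters and pyridin-4-yl leaves. The third step, a number 4 percentage points lower from compound 1 to compound 2 (within the scatter), shows that exchanging one halogenated phenyl for another stayed within the scatter, so the particular halogen pattern of 2,5-difluorophenyl is not expected to matter much.

Compound 4 is therefore expected to fall back toward the numbers of compound 1 and compound 2, an expected step of a number 60 percentage points lower from compound 3 to compound 4 (beyond the scatter). The estimate for compound 4 in this assay is -75%, with a range from -90% to -50%.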

Compound 4, a percentage reported as activity, at one concentration (the size of the read-out at that concentration, not a potency): -80%
Beside the measured number, compound 4's estimate is 5 percentage points above it; low and high end bracket the measured number.
By their numbers in this assay, from the lowest: compounds 2, 4 and 1 (each within the scatter of the next); then compound 3.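

In this assay the exchange at this amine nitrogen in a ring now reads in both directions: a number 65 percentage points lower from compound 3 to compound 4 (beyond the scatter) matches in size the earlier large steps in which pyridin-4-yl entered. A third halogen pattern also falls in with the other two, as a number 1 percentage points higher from compound 2 to compound 4 (within the scatter) and a number 3 percentage points lower from compound 1 to compound 4 (within the scatter) leave compound 1, compound 2 and compound 4 together, with compound 3 alone apart from them among these four compounds. No measurement given here accounts for the gap between the halogenated phenyl groups and pyridin-4-yl.

The compounds shown leave open whether an unsubstituted phenyl, or a phenyl carrying a methoxy group, would stay with the halogenated phenyl groups or move toward compound 3. They also leave open whether pyridin-2-yl or pyridin-3-yl would behave like pyridin-4-yl, and, since this read-out comes from one concentration only, whether compound 1, compound 2 and compound 4 would still stay together in a full concentration series.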